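Fluorination steps in two cytotoxicity series

A few compounds are considered here, and "the series" means these few. Any claim that something is new, unique, unknown or untested is made for them only; others in the source may bear on it.

Compound 1 `O=C(CSC(=S)N[C@H]1CCOC1=O)Nc1ccccc1F` and compound 2 `O=C(CSC(=S)N[C@H]1CCOC1=O)Nc1ccccc1` share one core, while compound 3 `O=C(CCl)Nc1ccc(C(=O)/C=C/c2ccc(F)cc2)cc1` and compound 4 `O=C(CCl)Nc1ccc(C(=O)/C=C/c2ccc(F)c(F)c2)cc1` share another; the difference between the two cores is not broken down here. In a functional assay on MCF7 cells (Homo sapiens) for cytotoxicity, read by MTT assay, with a stated time of 72 h (on this read-out higher numbers stand for weaker inhibition and lower numbers for stronger inhibition), compound 1 gives 28600 nM. For compound 2 the read-out in this assay is only a limit, > 128000 nM, namely (the limit of > 128000 nM in this assay, at which 1 of the 3 values shown sits). The change from compound 2 to compound 1, (fluoro in place of hydrogen on an aromatic carbon), gave an at least 4.4-fold lower number from compound 2 to compound 1 (0.65 log units; beyond the scatter). In this assay compound 3 gives 5470 nM, lower than compound 1. Compound 4 carries the same kind of change relative to compound 3, (fluoro in place of hydrogen on an aromatic carbon); in compound 1 the entering fluoro sits ortho to a large group, whereas in compound 4 it sits ortho to a fluoro group and meta to a large group, so the surroundings of the place differ. The step in this assay is expected to be a 1.6-fold lower number from compound 3 to compound 4 (0.19 log units; within the scatter), smaller than the earlier one because an at least 4.4-fold lower number from compound 2 to compound 1 (0.65 log units; beyond the scatter) started from a limit and concerned a differently placed fluoro. Compound 4 is therefore estimated at 3500 nM, between 1500 nM and 9000 nM.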

Compound 4, half-maximal inhibitory concentration: 2290 nM
Estimate against measurement, compound 4: 1.5-fold (0.18 log units) above; low and high end bracket the measured number.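

In this assay, fluoro in place of hydrogen on an aromatic carbon again lowers the number, with a 2.4-fold lower number from compound 3 to compound 4 (0.38 log units; beyond the scatter), so the direction of the change carries over from the core of compound 1 to the core of compound 3 in these two pairs: the same change on two cores in this assay, an at least 4.4-fold lower number (0.65 log units; beyond the scatter) from compound 2 to compound 1 and a 2.4-fold lower number (0.38 log units; beyond the scatter) from compound 3 to compound 4; the limit leaves it open whether they differ

The size of the step cannot be compared across the two cores, since compound 2 is held only by a limit: the limit of > 128000 nM in this assay, at which 1 of the 4 values shown sits.

Two pairs make no general rule for this change, and the entering fluoro has different surroundings in each, so the notes support a shared direction on these cores and nothing firmer.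

Open, from the compounds shown here alone, is whether a chloro or a methoxy group entering at the same place on the core of compound 3 would give a step like that of fluoro. Also open, going by these compounds, is whether the fluoro step on that core persists when the chloro of the side chain gives way to an amine.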